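Replacing oxan-4-yl with cyclopropyl in a soluble series

A few compounds are considered here, and "the series" means these few. Any claim that something is new, unique, unknown or untested is made for them only; others in the source may bear on it.

In a physicochemical assay for solubility, using the shake flask method, in phosphate buffer, measured as kinetic solubility, with a stated time of 20 h, at pH 6.5 (a lower number here means a less soluble compound, a higher number a more soluble compound), compound 1 (`Fc1ccc(-c2nc3cnc(Nc4ccc(C(F)(F)F)cn4)cc3[nH]2)cc1F`) reaches only a limit of the assay, < 5000 nM. Compound 2 (`FC(F)(F)c1ccc(Nc2cc3[nH]c(C4CCCC4)nc3cn2)nc1`) gives a number, 145000 nM, and compound 3 (`FC(F)(F)c1ccc(Nc2cc3[nH]c(C4CCOCC4)nc3cn2)nc1`) gives 155000 nM. Compound 3 thus stands level with compound 2, as the measured step shows: a 1.1-fold higher number from compound 2 to compound 3 (0.03 log units; within the scatter).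

Compound 4 (`FC(F)(F)c1ccc(Nc2cc3[nH]c(C4CC4)nc3cn2)nc1`), not yet measured, carries cyclopropyl in place of oxan-4-yl on an aromatic carbon.

For the measured compounds named here, three measured steps bear on this change, all at the same place. Two of them start from 3,4-difluorophenyl and are large: an at least 29-fold higher number from compound 1 to compound 2 (1.46 log units; beyond the scatter), and an at least 31-fold higher number from compound 1 to compound 3 (1.49 log units; beyond the scatter). They say little here, since compound 4 keeps a non-aromatic ring. The closer guide is the exchange of one non-aromatic ring for another, cyclopentyl for oxan-4-yl, which gave a 1.1-fold higher number from compound 2 to compound 3 (0.03 log units; within the scatter). No three-membered ring has been measured, so this comparison remains an extrapolation. In this assay, no step beyond the scatter is therefore expected, in either direction. The estimated change is a 1.1-fold lower number from compound 3 to compound 4 (0.04 log units; within the scatter). For compound 4, the expected value is 140000 nM, with an estimated range of 60000 nM to 300000 nM.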

Compound 4, solubility: < 5000 nM
Compound 4: only a limit was reported; the forecaster's own chance of this, stated with the estimate: 10%; at least 28-fold (1.44 log units) between middle value and limit.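

In this assay, the exchange of one non-aromatic ring for another at this place, on an aromatic carbon between two ring nitrogen atoms, no longer leaves the number unchanged: an at least 31-fold lower number from compound 3 to compound 4 (1.49 log units; beyond the scatter), and an at least 29-fold lower number from compound 2 to compound 4 (1.46 log units; beyond the scatter). A non-aromatic ring here therefore does not by itself go with a high number, and the identity of the ring counts in a way that the pair of compound 2 and compound 3 could not show, as cyclopropyl gives a large step where oxan-4-yl in place of cyclopentyl gave none beyond the scatter. The value of compound 4 is a limit and not a number: the limit of < 5000 nM in this assay, at which 2 of the 4 values shown sit.

On these data alone, the step from compound 1 to compound 4 cannot be read, as both of its values are limits, so how these two compare stays open. Also open, as far as these compounds go, is whether this large step belongs to the three-membered ring alone, or whether cyclobutyl, an open chain such as isopropyl, or an amine on the same carbon would stand with compound 2 and compound 3 or with compound 4.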